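Trading a dimethylpiperazine for an aminopiperidine

This account rests on a few compounds, and the source may have more. Where it says the series, first, only, none or still open, it means among the compounds named here.

Measured in a functional assay on V79 cells (Cricetulus griseus) for cytotoxicity, read by colony formation; a lower number here means a stronger inhibitor, a higher number a weaker inhibitor:
Compound 1 `CC1(CN)CCN(c2c(F)cc3c(=O)c(C(=O)O)cn(C4CC4)c3c2C(F)(F)F)C1`: 110 ug/mL
Compound 2 `CC1CN(c2c(F)cc3c(=O)c(C(=O)O)cn(C4CC4)c3c2F)CC(C)N1`: 150 ug/mL
Compound 3 `CC1CN(c2c(F)cc3c(=O)c(C(=O)O)cn(C4CC4)c3c2C(F)(F)F)CC(C)N1`: > 500 ug/mL, a limit and not a number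

Compound 3 stands only at a limit: the limit of > 500 ug/mL in this assay, at which 1 of the 3 values shown sits. Compound 4 `NC1CCCN(c2c(F)cc3c(=O)c(C(=O)O)cn(C4CC4)c3c2C(F)(F)F)C1` carries 3-aminopiperidin-1-yl in place of 3,5-dimethylpiperazin-1-yl on an aromatic carbon, ortho to a fluoro group and ortho to a trifluoromethyl group (3-aminopiperidin-1-yl in place of 3,5-dimethylpiperazin-1-yl on an aromatic carbon). Exchange at this same carbon gave an at least 4.5-fold higher number from compound 1 to compound 3 (0.65 log units; beyond the scatter). The exchange of fluoro for trifluoromethyl gave an at least 3.3-fold higher number from compound 2 to compound 3 (0.52 log units; beyond the scatter), and compound 4 keeps the trifluoromethyl group. Compound 1 also has that group without the 3,5-dimethylpiperazin-1-yl group and gives 110 ug/mL, so a lower number is expected in this assay. The expected step is an at least 3.8-fold lower number from compound 3 to compound 4 (0.58 log units; beyond the scatter). Compound 4 is estimated at 130 ug/mL, with an expected range of 45 ug/mL to 400 ug/mL.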

Compound 4, half-maximal inhibitory concentration: > 500 ug/mL
Compound 4 ended at the assay's limit; the forecaster's own chance of this, stated with the estimate: 12%; at least 3.8-fold (0.58 log units) between middle value and limit.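

In this assay compound 4 gives > 500 ug/mL, a limit and not a number. Compound 3 and compound 4 both stand at this limit, so the step between them cannot be read: the limit of > 500 ug/mL in this assay, at which 2 of the 4 values shown sit.

What is new is that 3,5-dimethylpiperazin-1-yl is not alone at this carbon in giving a weaker result than the 3-(aminomethyl)-3-methylpyrrolidin-1-yl group, for 3-aminopiperidin-1-yl also does so with the trifluoromethyl group kept, giving an at least 4.5-fold higher number from compound 1 to compound 4 (0.65 log units; beyond the scatter).

Which of compound 3 and compound 4 is the weaker stays open. So does whether a pyrrolidine carrying a plain amino group at this carbon would give a number inside the assay's range.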